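Bromo to methoxy on an aromatic carbon in compound 2

A few compounds are considered here, and "the series" means these few. Any claim that something is new, unique, unknown or untested is made for them only; others in the source may bear on it.

Compound 2 `Nc1scc(-c2ccc(Br)cc2)c1C(=O)c1ccc(Cl)cc1` stands lowest of the two measured compounds: in a functional assay on CHO cells for agonist activity at adenosine receptor A1 (Homo sapiens), read by fluorescence and ERK phosphorylation, with stated times of 30 min and 1.5 h, tested at 10 uM (a lower number here means a weaker effect, a higher number a stronger effect of the compound at the concentration tested), compound 2 gives 46%, whereas compound 1 `Nc1scc(-c2ccccc2)c1C(=O)c1ccc(Cl)cc1` gives 64%. For the measured compounds named here, the only measured step, a number 18 percentage points lower from compound 1 to compound 2 (beyond the scatter), came with bromo in place of hydrogen on an aromatic carbon. Compound 3 `COc1ccc(-c2csc(N)c2C(=O)c2ccc(Cl)cc2)cc1` differs from compound 2 by methoxy in place of bromo on an aromatic carbon. Going by the values given here, no measured step covers methoxy entering; the single step shows only that bromo on that aromatic carbon took the number down, so methoxy in place of bromo may undo part of that loss or leave it standing. Taken together, the expectation for compound 3 in this assay is a small rise, a number 8 percentage points higher from compound 2 to compound 3 (within the scatter), of a size close to the scatter. Compound 3 is therefore estimated at 54%, with a range from 34% to 72%.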

Compound 3, a percentage reported as activity, at one concentration (the size of the read-out at that concentration, not a potency): 55%
For compound 3 the middle estimate is 1 percentage points below the measured one; measured number inside the range.
By their numbers in this assay, from the lowest: compounds 2, 3 and 1 (each within the scatter of the next, the first and the last beyond it).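

Methoxy in place of bromo on this aromatic carbon gives a number 9 percentage points higher from compound 2 to compound 3 (within the scatter) in this assay, while methoxy in place of hydrogen gives a number 9 percentage points lower from compound 1 to compound 3 (within the scatter) at the same place. For the compounds shown here, compound 3 therefore cannot be separated from either neighbour, even though a number 18 percentage points lower from compound 1 to compound 2 (beyond the scatter) remains the one step at this position beyond the scatter. A substituent para to a large group thus does not have to bring a clear loss: the drop seen with bromo does not extend to methoxy, and no available data explain the difference between the two groups.

From the compounds shown here alone, whether an amine, a carboxylic acid or a longer chain such as ethoxy at this place would stay level with compound 1 remains open. These single-concentration read-outs also leave the potency of all three compounds open.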